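Swapping a sulfonyl for an ethyl group on the piperazine

A few compounds are considered here, and "the series" means these few. Any claim that something is new, unique, unknown or untested is made for them only; others in the source may bear on it.

Three compounds share one core and differ only in the group attached to its saturated ring. Compound 1 `Cc1nc(N2CCN(C3CCCC3)CC2)nc2ccc(NC(=O)COc3ccc(Cl)cc3)cc12` carries a cyclopentyl there and in an assay on CHO-K1 cells for displacement of a labelled ligand from melanin-concentrating hormone receptor 1 (Homo sapiens), with a stated time of 2 h (on this read-out lower numbers stand for stronger inhibition and higher numbers for weaker inhibition), gives 96 nM. Compound 3 `Cc1nc(N2CCC(C(=O)NC(C)C)CC2)nc2ccc(NC(=O)COc3ccc(Cl)cc3)cc12` carries an isopropyl amide on a piperidine and in this assay gives 15 nM. Compound 2 `Cc1nc(N2CCN(S(C)(=O)=O)CC2)nc2ccc(NC(=O)COc3ccc(Cl)cc3)cc12` carries a methylsulfonyl on the piperazine nitrogen. In this assay compound 2 gives only a limit, > 10000 nM, which is the limit of > 10000 nM in this assay, at which 1 of the 3 values shown sits. Within the data shown here, the step of an at least 100-fold higher number from compound 1 to compound 2 (2.01 log units; beyond the scatter) is therefore the only measured change that bears on the question here, and it runs from an alkyl group to the sulfonyl.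

Compound 4 `CCN1CCN(c2nc(C)c3cc(NC(=O)COc4ccc(Cl)cc4)ccc3n2)CC1` reverses that direction: ethyl in place of methylsulfonyl on an amine nitrogen in a ring. Because the step of an at least 100-fold higher number from compound 1 to compound 2 (2.01 log units; beyond the scatter) was large and lost activity on going to the sulfonyl, removing it for an ethyl is expected to restore much of it. The estimated step of an at least 50-fold lower number from compound 2 to compound 4 (1.69 log units; beyond the scatter) is large and toward stronger binding. Compound 4 is expected to give about 200 nM in this assay, within 40 nM to 1500 nM.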

Compound 4, half-maximal inhibitory concentration: 690 nM
The estimate for compound 4 lay 3.5-fold (0.54 log units) below the measured number; measured number inside the range.
By their numbers in this assay, from the lowest: compound 3; then compound 1; then compound 4. At a limit, above all of these: compound 2.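

Putting ethyl in place of methylsulfonyl on the amine nitrogen gives an at least 14-fold lower number from compound 2 to compound 4 (1.16 log units; beyond the scatter) in this assay, so the piperazine itself does not account for the loss seen in compound 2. The true size of that step is unknown, as the value for compound 2 is a limit of the assay and not a number: the limit of > 10000 nM in this assay, at which 1 of the 4 values shown sits.

The choice of alkyl group also counts, with a 7.2-fold higher number from compound 1 to compound 4 (0.86 log units; beyond the scatter) when ethyl replaces cyclopentyl, so having just any alkyl group on this nitrogen does not match the binding seen with cyclopentyl.

The compounds shown leave open how binding changes between ethyl and cyclopentyl, for example with an isopropyl group or a butyl chain on this nitrogen. They also leave open whether an acetyl group on the same nitrogen would behave like ethyl or like methylsulfonyl.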